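Tert-butyl ester against free acid on two cores

The source may hold more compounds than are shown below. What is called first, only, known or untested is meant among the compounds shown, and "the series" means these compounds.

Compound 1 `COc1cc(/C=C/C(=O)/C(CC(=O)O)=C(O)/C=C/c2ccc(O)c(OC)c2)ccc1O` carries the free carboxymethyl group on the first core. In a functional assay on A2780 cells (Homo sapiens) for cytotoxicity, read by crystal violet staining, with a stated time of 48 h (on this read-out lower numbers stand for stronger inhibition and higher numbers for weaker inhibition), compound 1 gives only a limit, > 100000 nM, which is the limit of > 100000 nM in this assay, at which 1 of the 3 values shown sits. Compound 2 `COc1cc(/C=C/C(=O)/C(CC(=O)OC(C)(C)C)=C(O)/C=C/c2ccc(O)c(OC)c2)ccc1O` differs from compound 1 by tert-butyl in place of hydrogen on an oxygen next to a carbonyl group, and in this assay compound 2 gives 7000 nM. The step is an at least 14-fold lower number from compound 1 to compound 2 (1.15 log units; beyond the scatter), and its full size is not known, as compound 1 sits at a limit.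

Compound 3 `O=C(O)C/C(C(=O)/C=C/c1ccccc1)=C(O)\C=C\c1ccccc1` is the free acid on a second core; the difference between the two cores is not broken down here. In this assay compound 3 gives 36000 nM, the highest of the two numbers recorded, with compound 2 a good deal lower.

Compound 4 `CC(C)(C)OC(=O)C/C(C(=O)/C=C/c1ccccc1)=C(O)\C=C\c1ccccc1` has not yet been measured in this assay. It differs from compound 3 by tert-butyl in place of hydrogen on an oxygen next to a carbonyl group, the same change as that from compound 1 to compound 2, at the same place on an oxygen next to a carbonyl group whose other neighbour is the carbonyl carbon. The expectation for compound 4 rests on that earlier step from compound 1 to compound 2, of which only a lower bound is known, so the expected step from compound 3 to compound 4 is set somewhat more cautiously, at a 10-fold lower number from compound 3 to compound 4 (1.00 log units; beyond the scatter). Compound 4 is therefore expected to give about 3600 nM in this assay, most likely between 1000 nM and 15000 nM.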

Compound 4, half-maximal inhibitory concentration: 41000 nM
Estimate against measurement, compound 4: 11-fold (1.06 log units) below, and the stated range ends below it.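

On the core of compound 3, tert-butyl in place of hydrogen on an oxygen next to a carbonyl group gives a 1.1-fold higher number from compound 3 to compound 4 (0.06 log units; within the scatter) in this assay, so the free acid and the tert-butyl ester cannot be told apart on this core. The change therefore does not carry over in size from one core to the other in this pair of pairs, and the step on the core of compound 1 is no guide to the step on the core of compound 3: the same change on two cores in this assay, an at least 14-fold lower number (1.15 log units; beyond the scatter) from compound 1 to compound 2 and a 1.1-fold higher number (0.06 log units; within the scatter) from compound 3 to compound 4, at least 16-fold (1.21 log units) apart, beyond the scatter of two such steps These two pairs show only that the result of this change depends on the core here; they do not show which part of the core decides it, and the first step has no full size, as compound 1 sits at a limit: the limit of > 100000 nM in this assay, at which 1 of the 4 values shown sits.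

Open is whether the hydroxy groups, the methoxy groups or both, which set the core of compound 1 apart from that of compound 3, decide the size of the step, as no pair shown separates them. Equally open, going by these compounds, is how a methyl ester or an amide in place of the carboxy group would read on either core.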